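Fluoro-indazole in place of the aza-ring on the ethylene core

A few compounds are considered here, and "the series" means these few. Any claim that something is new, unique, unknown or untested is made for them only; others in the source may bear on it.

Compound 1 `O=C(O)/C=C/c1ccc(/C(=C(/CCO)c2ccccc2)c2ccc3[nH]ncc3c2)cc1` gives > 1000 nM in a functional assay on MCF7 cells (Homo sapiens) for cytotoxicity, read by CellTiter-Glo, with a stated time of 5 days (a lower number here means a stronger inhibitor, a higher number a weaker inhibitor), a limit of the assay rather than a number. Compound 2 `O=C(O)/C=C/c1ccc(/C(=C(/CCCl)c2ccccc2)c2ccc3[nH]ncc3c2)cc1` gives 9 nM. Compound 3 `CC/C(=C(/c1ccc(/C=C/C(=O)O)cc1)c1cc2cn[nH]c2cn1)c1ccccc1` gives 442 nM.

Among the numbers shown, compound 3 stands highest, compound 2 being the nearest at a lower value. Within the data shown here, the one measured step, an at least 110-fold lower number from compound 1 to compound 2 (2.04 log units; beyond the scatter), concerns the chain and not the ring; compound 1 sits at the limit of > 1000 nM in this assay, at which 1 of the 3 values shown sits. Compound 4 `CC/C(=C(/c1ccc(/C=C/C(=O)O)cc1)c1cc(F)c2[nH]ncc2c1)c1ccccc1` differs from compound 3 by a group of 10 heavy atoms (7 carbon, 2 nitrogen, 1 fluorine; one five-membered aromatic ring with 2 hetero atoms, one six-membered aromatic ring of carbon only) in place of a group of 9 heavy atoms (6 carbon, 3 nitrogen; one five-membered aromatic ring with 2 hetero atoms, one six-membered aromatic ring with 1 hetero atom), on a double-bonded chain carbon bound to an aromatic carbon and a double-bonded chain carbon. Among the measured compounds shown here, no measured step matches this change, so the expectation rests only on compound 2 and compound 3 sharing the core while differing at both ring and chain. Compound 4 is expected to give 150 nM, between 40 nM and 600 nM, an expected step of a 2.9-fold lower number from compound 3 to compound 4 (0.47 log units; beyond the scatter).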

Compound 4, half-maximal inhibitory concentration: 7.5 nM
For compound 4 the middle estimate is 20-fold (1.30 log units) above the measured one; the measured number lies below the stated range.
By their numbers in this assay, from the lowest: compounds 4 and 2 (each within the scatter of the next); then compound 3. At a limit, above all of these: compound 1.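

In this assay, 7-fluoro-1H-indazol-5-yl entering on the double-bonded chain carbon gives a 59-fold lower number from compound 3 to compound 4 (1.77 log units; beyond the scatter). Among these compounds, the only earlier step lay on the chain, so this is the first sign that a change of the ring group at this place, with the rest of the compound held, can alone produce a large step. Nothing measured here accounts for its size.

The compounds shown leave open whether the fluorine or the loss of the ring nitrogen carries the step, since both change together. They also leave open how a chloro or a methoxy group in place of the fluorine would read.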